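Swapping the side chain for a chloroalkyl: cytotoxicity outlook

The compounds below may be only part of what the source reports. "The series", "measured", "known", "first", "only" and "open" are said of these compounds alone.

Measured compounds in an ADME assay on MT4 cells (Homo sapiens) for cytotoxicity, read by MTT assay, with a stated time of 5 days; a higher number here means that more compound is tolerated, a lower number that less compound is tolerated:
- compound 1, `CCCN(c1ccnc(Nc2ccc(C#N)cc2)n1)c1c(F)cc(-c2ccc(C#N)cc2)cc1F`, gives 212000 nM
- compound 2, `CC(C)N(c1ccnc(Nc2ccc(C#N)cc2)n1)c1c(F)cc(-c2ccc(C#N)cc2)cc1F`, gives 172000 nM
- compound 3, `CCC(C)CN(c1ccnc(Nc2ccc(C#N)cc2)n1)c1c(F)cc(-c2ccc(C#N)cc2)cc1F`, gives > 255000 nM

All three share one core and differ only in the chain on a nitrogen attached to an aromatic ring. For compound 3 the value is a limit of the assay, not a number (the limit of > 255000 nM in this assay, at which 1 of the 3 values shown sits). The steps between these chains were small: a 1.2-fold lower number from compound 1 to compound 2 (0.09 log units; within the scatter), an at least 1.2-fold higher number from compound 1 to compound 3 (0.08 log units; that floor lies within the scatter), and an at least 1.4-fold higher number from compound 2 to compound 3 (0.17 log units; that floor lies within the scatter). None of them moved the read-out beyond the scatter.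

Compound 4, `N#Cc1ccc(Nc2nccc(N(CCCCl)c3c(F)cc(-c4ccc(C#N)cc4)cc3F)n2)cc1`, carries a change at the same place: 2-chloroethyl in place of sec-butyl on a saturated chain carbon bound to a nitrogen on an aromatic ring. Cut one bond further out, the same difference reads 2-methylbutyl to 3-chloropropyl. For the measured compounds named here, nothing among the measured compounds contains a chlorine on this chain, so the measured steps speak only to changes in chain shape, and those were all within the scatter. On that basis no step beyond the scatter is expected, though the limit for compound 3 leaves its exact position open. Compound 4 is estimated at 200000 nM, with a range from 100000 nM to 300000 nM, which amounts to an expected step of an at least 1.2-fold lower number from compound 3 to compound 4 (0.10 log units; that floor lies within the scatter).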

Compound 4, half-maximal cytotoxic concentration: > 250000 nM
Compound 4 gave a limit, no number; the forecaster's own chance of this, stated with the estimate: 40%; at least 1.2-fold (0.09 log units) between middle value and limit.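

For the compounds shown here, a chlorine on this chain, which none of the earlier compounds carries, brought no fall in this assay: with 3-chloropropyl on the nitrogen, the readable steps are an at least 1.4-fold higher number from compound 2 to compound 4 (0.16 log units; that floor lies within the scatter) and an at least 1.1-fold higher number from compound 1 to compound 4 (0.07 log units; that floor lies within the scatter). The result for compound 4 is a limit of the assay, not a number: the limit of > 250000 nM in this assay, at which 1 of the 4 values shown sits. The result for compound 3 is a limit as well, so the step between these two compounds cannot be read: the limit of > 255000 nM in this assay, at which 1 of the 4 values shown sits.

From the compounds shown here alone, how far the true values of compound 3 and compound 4 lie past their limits stays unknown, so the chlorine's full effect on the read-out cannot be sized. Also open, going by these compounds, is whether an amine or a carboxylic acid in place of the chloro would still reach the limit in this assay.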